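Trifluoromethoxy for carbamoyl in an inactive series

The compounds below may be only part of what the source reports. "The series", "measured", "known", "first", "only" and "open" are said of these compounds alone.

Values in a functional assay on Jurkat cells (Homo sapiens) (a higher number here means a weaker inhibitor, a lower number a stronger inhibitor), read as half-maximal inhibitory concentration:
compound 1 `CC(C)[C@H](NC(=O)COc1cccc2ccccc12)C(=O)N[C@@H](CC(=O)O)C(=O)COc1ccc2ccccc2c1` gives > 100000 nM, a limit
compound 2 `CC(C)[C@H](NC(=O)COc1cccc2ccccc12)C(=O)N[C@@H](CC(=O)O)C(=O)COc1ccc(C(N)=O)cc1` gives > 100000 nM, a limit

Compound 2 gives > 100000 nM, which is a limit of the assay and not a number. Going by the values given here, the picture across the series is the limit of > 100000 nM in this assay, at which 2 of the 2 values shown sit, so no measured compound offers a numerical anchor.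

The next change leads to compound 3 `CC(C)[C@H](NC(=O)COc1cccc2ccccc12)C(=O)N[C@@H](CC(=O)O)C(=O)COc1ccc(OC(F)(F)F)cc1`, with trifluoromethoxy in place of carbamoyl on an aromatic carbon, para to a large group: trifluoromethoxy in place of carbamoyl on an aromatic carbon. The core of compound 1 and the rest of compound 2 stay as they are.

Among the compounds with values here, one measured step bears on this position, a step that the two limits leave unreadable from compound 1 to compound 2, and it replaced naphthalen-2-yl with 4-carbamoylphenyl. Within the data shown here, it gives no size to carry forward, and no measured step shows a change in either direction. In this assay no step beyond the scatter is therefore expected, and a further report at the limit is the likeliest outcome. The estimated change is a number no higher from compound 2 to compound 3 (the limit leaves the size open). Compound 3 is expected at 100000 nM, with an estimated range of 30000 nM to 200000 nM.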

Compound 3, half-maximal inhibitory concentration: 29100 nM
The estimate for compound 3 lay 3.4-fold (0.54 log units) above the measured number, and the stated range ends above it.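

In this assay this position proves able to move the read-out: compound 3, at 29100 nM, is the only compound shown with a number, and trifluoromethoxy in place of carbamoyl gives an at least 3.4-fold lower number from compound 2 to compound 3 (0.53 log units; beyond the scatter). With the same core, 4-(trifluoromethoxy)phenyl in place of naphthalen-2-yl gives an at least 3.4-fold lower number from compound 1 to compound 3 (0.53 log units; beyond the scatter), so the group on this oxygen matters, and both other groups shown here give a higher reading than 4-(trifluoromethoxy)phenyl. The step between the two compounds at the limit cannot be read, and both new steps give only a minimum size, with their true size left open: the limit of > 100000 nM in this assay, at which 2 of the 3 values shown sit.

Whether the drop belongs to trifluoromethoxy itself remains open, as the compounds shown do not tell how a methoxy group, a chlorine, a trifluoromethyl group or a nitrile would read at the same place on the ring. Also open, from the compounds shown here alone, is whether the number for compound 3 shifts further when this group is kept and the rest of the molecule changes, for example with an amide or an ester in place of the carboxylic acid.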